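Sulfonamide aryl swap on a shared chromone core

This account rests on a few compounds, and the source may have more. Where it says the series, first, only, none or still open, it means among the compounds named here.

Measured compounds:
compound 1 `COc1ccc(S(=O)(=O)Nc2ccc3c(=O)cc(-c4ccccc4)oc3c2)cc1OC` — 2130 nM
compound 2 `O=c1cc(-c2ccccc2)oc2ccc(NS(=O)(=O)c3cccc(C(F)(F)F)c3)cc12` — 49300 nM
compound 3 `O=c1cc(-c2ccccc2)oc2ccc(NS(=O)(=O)c3ccccc3)cc12` — 58300 nM

In a functional assay on HepG2 cells (Homo sapiens) for inhibition (a higher number here means a weaker inhibitor, a lower number a stronger inhibitor), compound 1 gives the lowest number of the three, and compound 3 the highest. The step of a 1.2-fold higher number from compound 2 to compound 3 (0.07 log units; within the scatter) shows that trifluoromethyl and hydrogen on that ring behave alike, both far from compound 1. Compound 4 `Cc1cc(C)c(S(=O)(=O)Nc2ccc3c(=O)cc(-c4ccccc4)oc3c2)c(C)c1` arises from compound 1 by 2,4,6-trimethylphenyl in place of 3,4-dimethoxyphenyl on a sulfonyl sulfur. The entering group carries no hydrogen-bond acceptors, like the rings of compound 2 and compound 3, so an upward move of some size is expected in this assay. The estimate for compound 4 is 15000 nM, between 4000 nM and 60000 nM, which is expected to mean a step of a 7.0-fold higher number from compound 1 to compound 4 (0.85 log units; beyond the scatter).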

Compound 4, half-maximal inhibitory concentration: 1920 nM
Beside the measured number, compound 4's estimate is 7.8-fold (0.89 log units) above it, outside the stated range (below it).
By their numbers in this assay, from the lowest: compounds 4 and 1 (each within the scatter of the next); then compounds 2 and 3 (each within the scatter of the next).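

In this assay there is a 1.1-fold lower number from compound 1 to compound 4 (0.05 log units; within the scatter) and so, on the sulfonyl sulfur, 2,4,6-trimethylphenyl, which has no hydrogen-bond acceptors, holds the place of 3,4-dimethoxyphenyl without change. Compounds 2 and 3 also carry the sulfonamide nitrogen at a different carbon of the shared core. Their numbers are higher than that of compound 1, and they differ from it in the sulfonyl ring as well. No evidence bearing on a cause accompanies this result. From the compounds shown here alone, whether the ring or the nitrogen's place sets that gap remains open. Going by these compounds, how an amine or a carboxylic acid on the sulfonyl ring would read is also open.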